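Adding a Methyl to the Alkenyl Chain: Expected Lipophilicity

This account rests on a few compounds, and the source may have more. Where it says the series, first, only, none or still open, it means among the compounds named here.

Compound 1 `C=CCN(C1=NCCN1)c1c(Br)cccc1Br`, compound 2 `C=C(C)CN(C1=NCCN1)c1c(Br)cccc1Br` and compound 3 `C=CCCN(C1=NCCN1)c1c(Br)cccc1Br` share a core and differ only in the unsaturated chain carried on the nitrogen. In a physicochemical assay for lipophilicity (on this read-out lower numbers stand for lower lipophilicity and higher numbers for higher lipophilicity), compound 1 gives -0.75, compound 2 gives -0.66 and compound 3 gives -0.63. The change from compound 1 to compound 2 is methyl in place of hydrogen on a double-bonded chain carbon bound to a saturated chain carbon; it made a step of a number 0.09 log units higher from compound 1 to compound 2 (within the scatter). The core of compound 3 differs from that of compound 1 by allyl in place of vinyl on a saturated chain carbon bound to a nitrogen on an aromatic ring, and the read-out shows a number 0.12 log units higher from compound 1 to compound 3 (within the scatter). Compound 4 `C=C(C)CCN(C1=NCCN1)c1c(Br)cccc1Br` awaits measurement in this assay; it differs from compound 3 by methyl in place of hydrogen on a double-bonded chain carbon bound to a saturated chain carbon, the same change as from compound 1 to compound 2, now made on the core of compound 3. Because the earlier step was a number 0.09 log units higher from compound 1 to compound 2 (within the scatter), a step of about a number 0.09 log units higher from compound 3 to compound 4 (within the scatter) is expected. Compound 4 is therefore estimated at -0.54 in this assay.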

Compound 4, distribution coefficient: 0.02
Beside the measured number, compound 4's estimate is 0.56 log units below it; the measured number lies above the stated range.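

In this assay, the same methyl in place of hydrogen gave a step of a number 0.09 log units higher from compound 1 to compound 2 (within the scatter) on one core but a step of a number 0.65 log units higher from compound 3 to compound 4 (beyond the scatter) on the other, so the size of this step did not carry over from one core to the other. Compound 4 also sits clear of the remaining compounds, with a number 0.68 log units higher from compound 2 to compound 4 (beyond the scatter) and a number 0.77 log units higher from compound 1 to compound 4 (beyond the scatter) as well. These two pairs show that the step can differ between cores, but they set no rule for the series, and nothing available explains the difference.

Still open, on these data alone, is how the same methyl would act on a longer chain. An ethyl in place of that methyl is also an open case.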